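Positional isomer step: compound 3 to compound 4

The source may hold more compounds than are shown below. What is called first, only, known or untested is meant among the compounds shown, and "the series" means these compounds.

Measured so far, in an assay for inhibition of Amine oxidase [flavin-containing] B (Homo sapiens), read by fluorescence and spectrophotometry, using microsomes, with stated times of 30 min and 20 min; a higher number here means a weaker inhibitor, a lower number a stronger inhibitor:
compound 1, `CC(C)c1noc(-c2ccc(C3=NCCN3)cc2)n1`: 230 nM
compound 2, `c1ccc(OCc2noc(-c3ccc(C4=NCCN4)cc3)n2)cc1`: 9980 nM
compound 3, `Clc1cccc(-c2noc(-c3ccc(C4=NCCN4)cc3)n2)c1`: 64 nM

Compound 3 gives the lowest number of the three. Its nearest neighbour is compound 1, a 3.6-fold lower number from compound 1 to compound 3 (0.56 log units; beyond the scatter); its furthest is compound 2, a 160-fold lower number from compound 2 to compound 3 (2.19 log units; beyond the scatter). The remaining step, a 43-fold higher number from compound 1 to compound 2 (1.64 log units; beyond the scatter), is also large.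

Compound 4 is `Clc1ccccc1-c1noc(-c2ccc(C3=NCCN3)cc2)n1`; the change is 2-chlorophenyl in place of 3-chlorophenyl on an aromatic carbon. For the measured compounds named here, none of the measured steps bears on it directly: all three exchange the whole group for a different one, none shifts the same group within its ring. No guidance exists for the direction, so the expected step is a 1.7-fold higher number from compound 3 to compound 4 (0.24 log units; within the scatter), within the scatter. Compound 4 is therefore estimated at 110 nM, range 25 nM to 500 nM.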

Compound 4, half-maximal inhibitory concentration: 30 nM
Estimate against measurement, compound 4: 3.7-fold (0.56 log units) above, within the range that was stated.
By their numbers in this assay, from the lowest: compound 4; then compound 3; then compound 1; then compound 2.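

In this assay, 2-chlorophenyl in place of 3-chlorophenyl gives a 2.1-fold lower number from compound 3 to compound 4 (0.33 log units; beyond the scatter), the first sign in the series that moving the chlorine within the same ring shifts the number, though only modestly. Against the other groups at this position, the steps are a 7.7-fold lower number from compound 1 to compound 4 (0.88 log units; beyond the scatter) and a 330-fold lower number from compound 2 to compound 4 (2.52 log units; beyond the scatter), and compound 4 is the strongest inhibitor of the four. Open, as far as these compounds go, is whether 2-fluorophenyl, 2-methoxyphenyl or 4-chlorophenyl would continue or break this order. No measurement shown gives a reason for the shift.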